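A ring exchange at the limit of the assay

The source may report more compounds than this note shows. Statements on the series, on what has been measured and on what is new or still open speak of the compounds shown alone.

Measured in a functional assay on the whole organism for antagonist activity, with Mus musculus as the target; on this read-out lower numbers stand for an effect already at smaller amounts and higher numbers for an effect only at larger amounts of compound
Compound 1 `COC(=O)N(C)CC#CCn1ccnc1` gives > 100 mg/kg
Compound 2 `CCOC(=O)N(C)CC#CCN1CCCC1` gives > 100 mg/kg

For compound 2 the entry > 100 mg/kg is a limit of the assay and not a number. Both compounds rest on the limit of > 100 mg/kg in this assay, at which 2 of the 2 values shown sit, and no number is available for either. Compound 3 `CCOC(=O)N(C)CC#CCn1ccnc1` follows from compound 2 by one change (1H-imidazol-1-yl in place of pyrrolidin-1-yl on a saturated chain carbon bound to a triple-bonded carbon), with 1H-imidazol-1-yl in place of pyrrolidin-1-yl on a saturated chain carbon bound to a triple-bonded carbon. Compound 1 already carries 1H-imidazol-1-yl, and its entry > 100 mg/kg is also only a limit. In this assay the expected change is none beyond the scatter (a number no higher from compound 2 to compound 3 (the limit leaves the size open)). Compound 3 is estimated at 100 mg/kg (range 40 mg/kg to 250 mg/kg).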

Compound 3, dose for half-maximal effect: 97 mg/kg
Compound 3: middle estimate off by 1.0-fold (0.01 log units), on the high side, within the range that was stated.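

In this assay, 1H-imidazol-1-yl in place of pyrrolidin-1-yl gives an at least 1.0-fold lower number from compound 2 to compound 3 (0.01 log units; that floor lies within the scatter), and this is only a floor, so the true size of the step stays unread. Methyl in place of hydrogen on a saturated chain carbon bound to an oxygen next to a carbonyl group gives an at least 1.0-fold lower number from compound 1 to compound 3 (0.01 log units; that floor lies within the scatter), again only a floor. What is new is that compound 3 carries a number, while the other two entries rest on a limit: the limit of > 100 mg/kg in this assay, at which 2 of the 3 values shown sit.

The compounds shown leave open whether a piperidine ring in place of 1H-imidazol-1-yl would also give a number. They also leave open what a propyl group would do in place of that methyl or ethyl.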